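The source may report more compounds than this note shows. Statements on the series, on what has been measured and on what is new or still open speak of the compounds shown alone.

Among the compounds with values here, in a physicochemical assay for lipophilicity, read by HPLC, measured as chromatographic lipophilicity (on this read-out higher numbers stand for higher lipophilicity and lower numbers for lower lipophilicity), compound 2 `CCC/N=C1\S/C(=C\c2ccc(C(=O)NCC(=O)N(C)C)cc2)C(=O)N1c1ccccc1O` gives 1.9, the only actual number so far. Compound 1 `CCC/N=C1\S/C(=C\c2ccc(C(=O)OC)cc2)C(=O)N1c1ccccc1C` gives > 4.4, which is a limit of the assay and not a number. Compound 3 `CCC/N=C1\S/C(=C\c2ccc(CCC(=O)OC)cc2)C(=O)N1c1ccccc1O` differs from compound 2 in one place: 2-(methoxycarbonyl)ethyl in place of ((dimethylcarbamoyl)methyl)carbamoyl on an aromatic carbon, with 2-(methoxycarbonyl)ethyl in place of ((dimethylcarbamoyl)methyl)carbamoyl on an aromatic carbon, para to a large group. Within the data shown here, no measured pair shows this change. A large upward move in this assay, well beyond the scatter, is expected, estimated as a number 1.80 log units higher from compound 2 to compound 3 (beyond the scatter). The estimated value for compound 3 is 3.7, with an expected range of 3.1 to 4.3.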

Compound 3, distribution coefficient: 3.5
For compound 3 the middle estimate is 0.20 log units above the measured one; the measured number falls inside the stated range.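

With the change at this aromatic carbon, para to a large group, the reading in this assay comes out a number 1.60 log units higher from compound 2 to compound 3 (beyond the scatter). Within the data shown here, this is the first step that can be read at this position, and it shows that the reading depends strongly on the group placed there. The leaving group has 9 heavy atoms and 1 hydrogen-bond donor, the entering group 6 and 0 donors, and this single step cannot tell these differences apart.

From the compounds shown here alone, how a carboxylic acid, an amine or a longer chain at this position would read remains open. The upper end of the scale also remains unresolved: the limit of > 4.4 in this assay, at which 1 of the 3 values shown sits.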